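The compounds below may be only part of what the source reports. "The series", "measured", "known", "first", "only" and "open" are said of these compounds alone.

Of the compounds shown here, three built on a shared core have been measured in a functional assay on KB-V1 cells (Homo sapiens) for cytotoxicity, read by MTT assay, with a stated time of 72 h; a higher number here means a weaker inhibitor, a lower number a stronger inhibitor. Compound 1 `O=C1Nc2ccccc2/C1=N/NC(=S)Nc1cccc2ccccc12` gives 2210 nM, compound 2 `O=C1Nc2ccccc2/C1=N/NC(=S)Nc1ccccc1` gives 1470 nM, and compound 3 `O=C1Nc2ccccc2/C1=N/NC(=S)Nc1c(F)cc(F)cc1F` gives 7280 nM. Compound 2 has the lowest number of the three; its value and that of compound 1 lie within the scatter, while compound 3 stands beyond it with the higher number. Compound 4 `CCCC1CCC(c2ccc(NC(=S)N/N=C3\C(=O)Nc4ccccc43)cc2)CC1` differs from compound 2 by a single change: 4-propylcyclohexyl in place of hydrogen on an aromatic carbon. Within the data shown here, no measured pair shows such a step, so the direction rests on expectation alone: a modest change, if any, is expected, with the number somewhat more likely to fall than to rise. The step from compound 2 to compound 4 is estimated at a 1.5-fold lower number from compound 2 to compound 4 (0.17 log units; within the scatter). Compound 4 is accordingly expected to give 1000 nM, between 300 nM and 4000 nM.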

Compound 4, half-maximal inhibitory concentration: 11000 nM
Estimate against measurement, compound 4: 11-fold (1.04 log units) below; measured number outside the range, above it.
By their numbers in this assay, from the lowest: compounds 2 and 1 (each within the scatter of the next); then compounds 3 and 4 (each within the scatter of the next).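

Among these compounds, with the change on this aromatic carbon, 4-propylcyclohexyl in place of hydrogen, this assay shows a 7.5-fold higher number from compound 2 to compound 4 (0.87 log units; beyond the scatter), the first single-place step. The earlier compounds shown here formed no such step, so only now is there a sign that this position does not take this group without a loss of activity. The available data offer no measured basis for explaining that loss.

On these data alone, it remains open whether the cyclohexyl ring or the propyl chain carries the effect. Whether a plain propyl chain or an amine on this carbon would also raise the number is equally unsettled.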